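Swapping 2,4-difluorophenyl for 4-hydroxyphenyl

The source may report more compounds than this note shows. Statements on the series, on what has been measured and on what is new or still open speak of the compounds shown alone.

- compound 1 (`O=S(=O)(/C=C/c1ccc(Cl)cc1Cl)Cc1ccc(Nc2ncnc3ccccc23)cc1`) : 4000 nM
- compound 2 (`O=S(=O)(/C=C/c1ccc(F)cc1F)Cc1ccc(Nc2ncnc3ccccc23)cc1`) : > 100000 nM (a limit of the assay, not a number)

Both values come from a functional assay on U-251 cells (Homo sapiens); a higher number here means a weaker inhibitor of growth, a lower number a stronger inhibitor of growth. Going by these compounds, compound 2 stands at the limit of > 100000 nM in this assay, at which 1 of the 2 values shown sits, so it is the weaker of the two, and its exact position is unknown.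

The next compound is compound 3 (`O=S(=O)(/C=C/c1ccc(O)cc1)Cc1ccc(Nc2ncnc3ccccc23)cc1`). The change is 4-hydroxyphenyl in place of 2,4-difluorophenyl on a double-bonded chain carbon bound to a double-bonded chain carbon: 4-hydroxyphenyl in place of 2,4-difluorophenyl, on a double-bonded chain carbon bound to a double-bonded chain carbon. The rest of the molecule stays the same.

Among the measured compounds shown here, one measured step bears on this, made at the same place: an at least 25-fold higher number from compound 1 to compound 2 (1.39 log units; beyond the scatter). It shows that the group here can shift this assay by a large amount. For the measured compounds named here, it cannot show what a 4-hydroxyphenyl group does, since no compound carrying one has been measured. Going by the values given here, with compound 1 at 4000 nM as the only true number, a move toward lower numbers is expected. Compound 3 may also stay at the limit. The expected change is an at least 5.0-fold lower number from compound 2 to compound 3 (0.69 log units; beyond the scatter), a rough estimate. Compound 3 is estimated at 20000 nM, with an expected range of 3000 nM to 100000 nM.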

Compound 3, concentration for 50% growth inhibition: 300 nM
Beside the measured number, compound 3's estimate is 67-fold (1.82 log units) above it; measured number outside the range, below it.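

In this assay, the group on this double-bonded chain carbon can push the number down as well as up, and 4-hydroxyphenyl in place of 2,4-difluorophenyl gives an at least 330-fold lower number from compound 2 to compound 3 (2.52 log units; beyond the scatter). The gain also holds against a true number rather than a limit, as 4-hydroxyphenyl in place of 2,4-dichlorophenyl gives a 13-fold lower number from compound 1 to compound 3 (1.12 log units; beyond the scatter), which makes compound 3 the strongest inhibitor of growth of the three and shows that neither halogen-bearing ring is needed for activity here. Compound 2 sits at a limit of the assay and not at a number, so the first of these steps gives only a bound on its size: the limit of > 100000 nM in this assay, at which 1 of the 3 values shown sits.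

The change from either halogen-bearing ring to 4-hydroxyphenyl removes two halogen atoms and adds a hydroxyl group in one move, so the compounds shown cannot tell which of these matters, and they give no reason for the gain. An unsubstituted phenyl ring would test the loss of the halogens alone, while 4-methoxyphenyl and 4-aminophenyl would test whether the hydroxyl group itself can be replaced.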